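Trifluoromethyl to chloro on the shared core

The compounds below may be only part of what the source reports. "The series", "measured", "known", "first", "only" and "open" are said of these compounds alone.

Measured so far:
compound 1, `O=C1O/C(=C\Cn2cc(C(F)(F)F)c(=O)[nH]c2=O)C(OCc2ccccc2)=C1OCc1ccccc1`: 3600 nM in a functional assay on FM3A cells (Mus musculus) for inhibition; on this read-out higher numbers stand for weaker inhibition and lower numbers for stronger inhibition
compound 2, `O=C1O/C(=C\Cn2cnc3c(-n4cccc4)ncnc32)C(OCc2ccccc2)=C1OCc1ccccc1`: > 200000 nM in this assay, a limit of the assay and not a number

Within the data shown here, compound 1 supplies the only number in this assay among the two measured compounds; the other value, for compound 2, is a limit (the limit of > 200000 nM in this assay, at which 1 of the 2 values shown sits). Among the measured compounds shown here, no pair of measured compounds differs in one place, so no measured step sets a scale for what a single change does here.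

Compound 3, `O=C1O/C(=C\Cn2cc(Cl)c(=O)[nH]c2=O)C(OCc2ccccc2)=C1OCc1ccccc1`, awaits measurement in this assay. It differs from compound 1 by chloro in place of trifluoromethyl on an aromatic carbon. The exchange leaves hydrogen-bond donors and acceptors unchanged, and the measured pairs show nothing about such a swap. The step from compound 1 to compound 3 is expected to be a 4.2-fold higher number from compound 1 to compound 3 (0.62 log units; beyond the scatter), a weakening beyond the scatter, though an unchanged value cannot be excluded. Compound 3 is estimated at 15000 nM, within a range from 3000 nM to 80000 nM.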

Compound 3, half-maximal inhibitory concentration: 16900 nM
The estimate for compound 3 lay 1.1-fold (0.05 log units) below the measured number; the measured number falls inside the stated range.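

In this assay, the aromatic carbon para to a group of 1 heavy atom now has its first measured step: chloro in place of trifluoromethyl gives a 4.7-fold higher number from compound 1 to compound 3 (0.67 log units; beyond the scatter). The number therefore responds to the group at this carbon, even though the exchange leaves hydrogen-bond donors and acceptors unchanged, and of the two groups measured here, trifluoromethyl gives the stronger inhibition. Nothing measured here accounts for the size of this step.

From the compounds shown here alone, it remains open whether bromo, methyl or a nitrile at this carbon would fall closer to trifluoromethyl or to chloro, and whether any group there would give a lower number than trifluoromethyl. A single step also leaves open whether the same exchange would have a similar effect with other groups on the rest of the shared core.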